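A few compounds are considered here, and "the series" means these few. Any claim that something is new, unique, unknown or untested is made for them only; others in the source may bear on it.

In a physicochemical assay for lipophilicity, read by HPLC, measured as chromatographic lipophilicity, at pH 7.4 (on this read-out higher numbers stand for higher lipophilicity and lower numbers for lower lipophilicity), compound 2 `CC(C)(C)C(=O)N1N=CCC1c1cocn1` gives 3, the middle of three numbers. Compound 1 `O=C(c1cccnc1)N1CCC(C(=O)N2N=CCC2c2ccccc2)CC1` lies lower at 2.6, and compound 3 `O=C(C1CCCCC1)N1N=CCC1c1ccccc1` lies much higher at 5.9, both gaps beyond the scatter. Compound 4 `CC(C)(C)C(=O)N1N=CCC1C1CCCC1` differs from compound 2 in one place: cyclopentyl in place of 1,3-oxazol-4-yl on a saturated ring carbon. Among the compounds with values here, no measured pair isolates this replacement. Compound 3 at 5.9 also lacks the 1,3-oxazol-4-yl group, but it differs from compound 2 in more than one place and offers only a loose guide. A rise beyond the scatter is expected, an estimated a number 1.90 log units higher from compound 2 to compound 4 (beyond the scatter). For compound 4 the estimated value is 4.9, with an expected range of 4.2 to 5.6.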

Compound 4, distribution coefficient: 6.7
Beside the measured number, compound 4's estimate is 1.80 log units below it; measured number outside the range, above it.
By their numbers in this assay, from the lowest: compound 1; then compound 2; then compound 3; then compound 4.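

The saturated ring carbon is a sensitive position in this assay: with the rest of the molecule unchanged, cyclopentyl in place of 1,3-oxazol-4-yl gives a large step, a number 3.70 log units higher from compound 2 to compound 4 (beyond the scatter). Both groups have 5 heavy atoms, so the step arises without any change in that count, while the 2 hydrogen-bond acceptors leave with the oxazole. No measurement shown gives a reason for the size of this step. Still open, going by these compounds, is whether the acceptors or the aromatic ring matter more, and how an amine or a carboxylic acid would read at this position.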